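This account rests on a few compounds, and the source may have more. Where it says the series, first, only, none or still open, it means among the compounds named here.

- compound 1 `CCCCCC(=O)NCC(C)(C)CC1=C(O)C(=O)c2ccccc2C1=O`: 46600 nM
- compound 2 `CCCCCCCC(=O)NCC(C)(C)CC1=C(O)C(=O)c2ccccc2C1=O`: 18400 nM
- compound 3 `CCCCCCC(C)C(=O)NCC(C)(C)CC1=C(O)C(=O)c2ccccc2C1=O`: 15500 nM

In an ADME assay on Vero cells (Chlorocebus sabaeus) for cytotoxicity, read by reporter gene assay, with a stated time of 4 days (on this read-out higher numbers stand for weaker inhibition and lower numbers for stronger inhibition), compound 1 has the highest of the three numbers. Compound 4 `CCCCCCC(=O)OCC(C)(C)CC1=C(O)C(=O)c2ccccc2C1=O` differs from it in one place: (hexylcarbonyl)oxy in place of (pentylcarbonyl)amino on a saturated chain carbon, three bonds along the chain from a double-bonded ring carbon. It has (hexylcarbonyl)oxy in place of (pentylcarbonyl)amino on a saturated chain carbon, three bonds along the chain from a double-bonded ring carbon. Within the data shown here, no measured step makes this swap, so only chain changes can guide the expectation. There is a 2.5-fold lower number from compound 1 to compound 2 (0.40 log units; beyond the scatter) and a 3.0-fold lower number from compound 1 to compound 3 (0.48 log units; beyond the scatter), both modest, while a 1.2-fold lower number from compound 2 to compound 3 (0.07 log units; within the scatter) is small. A modest move to a lower number is therefore expected, though with much uncertainty. The expected change is a 1.7-fold lower number from compound 1 to compound 4 (0.22 log units; within the scatter). For compound 4 the estimate is 28000 nM, with an expected range of 11000 nM to 60000 nM.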

Compound 4, half-maximal inhibitory concentration: 99300 nM
Compound 4: the middle estimate sits 3.5-fold (0.55 log units) below what was measured; measured number outside the range, above it.
By their numbers in this assay, from the lowest: compounds 3 and 2 (each within the scatter of the next); then compound 1; then compound 4.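

In this assay, (hexylcarbonyl)oxy in place of (pentylcarbonyl)amino gives a 2.1-fold higher number from compound 1 to compound 4 (0.33 log units; beyond the scatter), the only step shown that raises the number beyond the scatter, so changes at this position can move it in either direction. The swap removes the one hydrogen-bond donor, replaces nitrogen with oxygen and adds a carbon all at once, so the step cannot be assigned to any one of these. No measurement here explains the rise.

A (pentylcarbonyl)oxy group would keep the chain of compound 1 and separate these changes. From the compounds shown here alone, how a simple amine would behave at this position remains open.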